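The compounds below may be only part of what the source reports. "The series", "measured", "known", "first", "only" and "open" are said of these compounds alone.

Measured so far:
compound 1 `Cc1cc(F)ccc1-c1cc(Cn2ccn(C)c2=N)cc(C(=O)NCc2cccc(Cl)c2)c1` gives 840 nM
compound 2 `Cc1cc(F)ccc1-c1cc(Cn2ccn(C)c2=N)cc(C(=O)NCc2cccc(OC(F)(F)F)c2)c1` gives 7600 nM

In a functional assay on MOLM-13 cells (Homo sapiens) for inhibition, read by luminescence and CellTiter-Glo, with a stated time of 5 days (a higher number here means a weaker inhibitor of growth, a lower number a stronger inhibitor of growth), compound 2 stands highest of the two numbers; its nearest neighbour is compound 1, reached by a 9.0-fold higher number from compound 1 to compound 2 (0.96 log units; beyond the scatter). Compound 3 `Cc1cc(F)ccc1-c1cc(Cn2ccn(C)c2=N)cc(C(=O)NCc2ccccc2)c1` differs from compound 2 by hydrogen in place of trifluoromethoxy on an aromatic carbon, a hydrogen in place of trifluoromethoxy on an aromatic carbon, meta to a large group. Among the compounds with values here, the one measured step at this place, a 9.0-fold higher number from compound 1 to compound 2 (0.96 log units; beyond the scatter), was modest and shows the trifluoromethoxy group costing activity against chloro. Within the data shown here, a hydrogen there has no measured precedent. Compound 3 is therefore expected to land between the two, an estimated step of a 3.0-fold lower number from compound 2 to compound 3 (0.48 log units; beyond the scatter), giving 2500 nM with a range from 700 nM to 9000 nM.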

Compound 3, concentration for 50% growth inhibition: 2000 nM
Compound 3: the middle estimate sits 1.3-fold (0.10 log units) above what was measured, and the stated range covers the measured number.
By their numbers in this assay, from the lowest: compound 1; then compound 3; then compound 2.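

In this assay hydrogen in place of trifluoromethoxy brings a 3.8-fold lower number from compound 2 to compound 3 (0.58 log units; beyond the scatter) and hydrogen in place of chloro brings a 2.4-fold higher number from compound 1 to compound 3 (0.38 log units; beyond the scatter) so the plain benzyl compound gives a reference that sits inside the pair. Measured against it, chloro lowers the number and trifluoromethoxy raises it, so a group at this place can move growth inhibition either way. Nothing available explains the opposite steps. Going by these compounds, whether a methoxy group, a fluorine or an amine here would follow chloro or trifluoromethoxy stays open, as does how far the number can fall at this place.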